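This account rests on a few compounds, and the source may have more. Where it says the series, first, only, none or still open, it means among the compounds named here.

Going by the values given here, in a functional assay on HCC1937 cells (Homo sapiens) for antiproliferative activity, read by CCK-8 assay, with a stated time of 72 h (a lower number here means a stronger inhibitor, a higher number a weaker inhibitor), compound 2 `N#Cc1ccc(C(=O)Nc2cccc(-c3oc4cc(-c5ccc(F)cc5)ccc4c(=O)c3O)c2)cc1` gives 2990 nM, the lower of the two numbers so far, while compound 1 `Cc1ccc(C(=O)Nc2cccc(-c3oc4cc(-c5ccc(F)cc5)ccc4c(=O)c3O)c2)cc1` gives 7110 nM. Among the compounds with values here, the single measured step, a 2.4-fold lower number from compound 1 to compound 2 (0.38 log units; beyond the scatter), turns on cyano in place of methyl on an aromatic carbon. Compound 3 `O=C(Nc1cccc(-c2oc3cc(-c4ccc(F)cc4)ccc3c(=O)c2O)c1)c1ccc(-c2ccccc2)cc1` differs from compound 2 by phenyl in place of cyano on an aromatic carbon, para to a large group. Within the data shown here, no measured step exchanges cyano for phenyl, so that step gives only a rough guide. For compound 3 the expected step is a 1.2-fold higher number from compound 2 to compound 3 (0.07 log units; within the scatter), not beyond the scatter. Compound 3 is therefore estimated at 3500 nM, within 1200 nM to 10000 nM in this assay.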

Compound 3, half-maximal inhibitory concentration: 44100 nM
The estimate for compound 3 lay 13-fold (1.10 log units) below the measured number; measured number above the stated range.
By their numbers in this assay, from the lowest: compound 2; then compound 1; then compound 3.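

At this place, on an aromatic carbon para to a large group, methyl and cyano stay within a modest step of each other, but phenyl does not: it gives a 15-fold higher number from compound 2 to compound 3 (1.17 log units; beyond the scatter), and a 6.2-fold higher number from compound 1 to compound 3 (0.79 log units; beyond the scatter). In this assay, a terminal aromatic ring here therefore costs far more than the exchange of methyl for cyano gains. No measurement given here accounts for this loss. On these data alone, it remains open whether the loss tracks the added heavy atoms or the aromatic ring itself. A cyclohexyl ring or a methoxy group at this place would help separate the two.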